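The source may report more compounds than this note shows. Statements on the series, on what has been measured and on what is new or still open speak of the compounds shown alone.

Four related amides are compared in a functional assay on A-431 cells (Homo sapiens) for cytotoxicity, read by MTT assay, with a stated time of 48 h; on this read-out lower numbers stand for stronger inhibition and higher numbers for weaker inhibition. Compound 1 `CCCCCCCCCCCCNC(=O)[C@@H](NC(=O)/C=C/c1ccccc1)[C@@H](C)O` is the starting point. In this assay compound 1 reaches only > 200000 nM, which is a limit of the assay and not a number, the same boundary as the limit of > 200000 nM in this assay, at which 1 of the 3 values shown sits. Compound 2 `C/C=C/C=C/C(=O)N[C@H](C(=O)NCCCCCCCCCCCC)[C@@H](C)O` differs from compound 1 by prop-1-en-1-yl in place of phenyl on a double-bonded chain carbon bound to a double-bonded chain carbon. In this assay compound 2 gives 171000 nM, a change of an at least 1.1-fold lower number from compound 1 to compound 2 (0.06 log units; that floor lies within the scatter). Compound 3 `CCCCCCCCCCCCCCNC(=O)[C@@H](NC(=O)/C=C/c1ccccc1)[C@@H](C)O` differs from compound 1 by ethyl in place of hydrogen on a saturated chain carbon, ten or more bonds along the chain from an amide-type nitrogen, and in this assay compound 3 gives 64900 nM, which is the step of an at least 3.0-fold lower number from compound 1 to compound 3 (0.48 log units; beyond the scatter). Compound 3 thus holds the lowest number among the measured compounds. Compound 4 `C/C=C/C=C/C(=O)N[C@H](C(=O)NCCCCCCCCCCCCCC)[C@@H](C)O` has not yet been measured. For the measured compounds named here, it differs from compound 3 by prop-1-en-1-yl in place of phenyl on a double-bonded chain carbon bound to a double-bonded chain carbon, the same change at the same place as the one made from compound 1 to compound 2, now on the core of compound 3. That earlier step is known only as a floor, so its true size is uncertain. Compound 4 is therefore expected to move by a 1.4-fold lower number from compound 3 to compound 4 (0.16 log units; within the scatter). Compound 4 is estimated at about 45000 nM, with a likely range from 15000 nM to 130000 nM.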

Compound 4, half-maximal inhibitory concentration: > 200000 nM
Compound 4: no number, only a limit (the forecaster's own chance of this, stated with the estimate: 5%); middle value at least 4.4-fold (0.64 log units) from the limit.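

In this assay, the swap of phenyl for prop-1-en-1-yl does not act alike on the two cores, and on the core of compound 3 it gives an at least 3.0-fold higher number from compound 3 to compound 4 (0.48 log units; beyond the scatter): the same change on two cores in this assay, an at least 1.1-fold lower number (0.06 log units; that floor lies within the scatter) from compound 1 to compound 2 and an at least 3.0-fold higher number (0.48 log units; beyond the scatter) from compound 3 to compound 4, at least 3.6-fold (0.55 log units) apart, beyond the scatter of two such steps

The ethyl in place of hydrogen on the saturated chain also acts differently on the two cores, and with the prop-1-en-1-yl group present it gives an at least 1.1-fold higher number from compound 2 to compound 4 (0.06 log units; that floor lies within the scatter): the same change on two cores in this assay, an at least 3.0-fold lower number (0.48 log units; beyond the scatter) from compound 1 to compound 3 and an at least 1.1-fold higher number (0.06 log units; that floor lies within the scatter) from compound 2 to compound 4, at least 3.6-fold (0.55 log units) apart, beyond the scatter of two such steps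

The value of compound 4, > 200000 nM, is a limit of the assay and not a number, so these gaps are known only as floors, and the four compounds show that the change does not carry over here without showing why.

The compounds shown leave open how the same swap would behave on a longer chain. They also leave open whether a carboxylic acid in place of phenyl would give a number clear of the limit.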